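A few compounds are considered here, and "the series" means these few. Any claim that something is new, unique, unknown or untested is made for them only; others in the source may bear on it.

Working notes on the series. Three analogues sharing one core have been measured in a functional assay (aorta) with Oryctolagus cuniculus as the target; on this read-out higher numbers stand for weaker binding and lower numbers for tighter binding. Compound 1 `Cc1ccnc2c1nc(C(C)C)n2Cc1ccc(-c2ccccc2C(=O)O)cc1` gives 31.6 nM, compound 2 `Cc1ccnc2c1nc(C1CCC1)n2Cc1ccc(-c2ccccc2C(=O)O)cc1` gives 5.01 nM, and compound 3 `COCc1nc2c(C)ccnc2n1Cc1ccc(-c2ccccc2C(=O)O)cc1` gives 79.4 nM. Compound 3 carries the highest number of the three: the nearest value belongs to compound 1, with a 2.5-fold higher number from compound 1 to compound 3 (0.40 log units; beyond the scatter), and the furthest to compound 2, with a 16-fold higher number from compound 2 to compound 3 (1.20 log units; beyond the scatter). The change a 6.3-fold lower number from compound 1 to compound 2 (0.80 log units; beyond the scatter) completes the picture of what the substituent on this aromatic carbon has done so far.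

The next compound, compound 4 `Cc1ccnc2c1nc(CCCO)n2Cc1ccc(-c2ccccc2C(=O)O)cc1`, keeps everything of compound 3 except one group: 2-hydroxyethyl in place of methoxy on a saturated chain carbon bound to an aromatic carbon. Within the data shown here, no measured step swaps a methoxy for a 2-hydroxyethyl; the three known steps all vary the whole group on the same aromatic carbon, moving between isopropyl, cyclobutyl and methoxymethyl, and they span modest to large sizes. They give no direct read on lengthening the chain and adding a hydroxyl while removing the methoxy. The expectation for compound 4 in this assay is therefore a step of a 1.3-fold higher number from compound 3 to compound 4 (0.10 log units; within the scatter), that is, no change clearly beyond the scatter, with the range kept wide. The estimate for compound 4 is 100 nM, between 30 nM and 320 nM.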

Compound 4, dissociation constant: 501 nM
Beside the measured number, compound 4's estimate is 5.0-fold (0.70 log units) below it; the measured number lies above the stated range.
By their numbers in this assay, from the lowest: compound 2; then compound 1; then compound 3; then compound 4.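

In this assay, the exchange of methoxy for 2-hydroxyethyl on a saturated chain carbon bound to an aromatic carbon gives a 6.3-fold higher number from compound 3 to compound 4 (0.80 log units; beyond the scatter), so the oxygen-bearing chain on this aromatic carbon has a clear effect on the read-out and compound 4 carries the highest number of the four. Against the groups without oxygen the gap is larger, with a 16-fold higher number from compound 1 to compound 4 (1.20 log units; beyond the scatter) and a 100-fold higher number from compound 2 to compound 4 (2.00 log units; beyond the scatter), the second being the widest step in the series, and both oxygen-bearing groups, methoxymethyl and 3-hydroxypropyl, now stand above both isopropyl and cyclobutyl in this small set. No available evidence accounts for the size of these steps.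

The step from compound 3 to compound 4 changes the chain length and the chain end together, so the compounds shown do not separate the contribution of each; a 3-methoxypropyl group or a plain butyl chain on this aromatic carbon would bear on that question. Also open, on these data alone, is whether a shorter 2-hydroxyethyl group, or an amine or a carboxylic acid at the end of the propyl chain, would follow compound 4 or lie closer to compound 3.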